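The source may report more compounds than this note shows. Statements on the series, on what has been measured and on what is new or still open speak of the compounds shown alone.

In a physicochemical assay for lipophilicity, at pH 7.4 (on this read-out lower numbers stand for lower lipophilicity and higher numbers for higher lipophilicity), compound 1 `Cc1cc(C(=O)NC(C)C)nn1Cc1cc(Cl)ccc1OCc1ccccc1` gives > 3.7, which is a limit and not a number. Going by the values given here, compound 2 `Cc1cc(C(=O)NN2CCOCC2)nn1Cc1cc(Cl)ccc1OCC(C)C` gives 3.1, the only actual number available so far, so it stands as the single firm reference point for the series. Among the compounds with values here, no measured step connects it with another compound.

Compound 3 `Cc1cc(NC(=O)OC(C)C)nn1Cc1cc(Cl)ccc1OCC(C)C` keeps the core of compound 2 and differs from it in one place: (isopropoxycarbonyl)amino in place of (morpholin-4-yl)carbamoyl on an aromatic carbon. There, (isopropoxycarbonyl)amino stands in place of (morpholin-4-yl)carbamoyl on an aromatic carbon, so the six-membered non-aromatic ring leaves and no ring enters. Within the data shown here, no measured pair shows this change directly, so the expectation rests on the structural change itself and on compound 2 as the starting point at 3.1.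

The expected result is a number 0.60 log units higher from compound 2 to compound 3 (beyond the scatter), an upward move in this assay beyond the usual scatter. Compound 3 might also be reported only as a limit and not as a number. For compound 3 the estimated value is 3.7, with an expected range from 3.3 to 4.2.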

Compound 3, distribution coefficient: > 3.7
Compound 3: only a limit was reported (the forecaster's own chance of this, stated with the estimate: 45%); the middle value lies on the limit itself.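

Going by these compounds alone, on an aromatic carbon of the shared core, (isopropoxycarbonyl)amino in place of (morpholin-4-yl)carbamoyl gives the first measured step in this assay, a number at least 0.60 log units higher from compound 2 to compound 3 (beyond the scatter). On these data alone, compound 3 gives > 3.7, which is a limit and not a number, so the step fixes a direction and a smallest size, while its full size stays unknown. This position therefore has a clear hold on the read-out, yet with this change the series moves out of the range where compounds can be told apart by number: the limit of > 3.7 in this assay, at which 2 of the 3 values shown sit.

The compounds shown do not separate the loss of the six-membered non-aromatic ring from the rest of the change, so it stays unclear which part carries the step, and a simple isopropyl carbamoyl group at this same aromatic carbon, on the core of compound 2, would be needed to begin dividing the two. As far as these compounds go, it also remains open whether a small amine or a carboxylic acid at this position would bring the value back to a firm number near that of compound 2.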